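Cytotoxicity notes on the series: expectation for compound 3

The compounds below may be only part of what the source reports. "The series", "measured", "known", "first", "only" and "open" are said of these compounds alone.

Compound 1 `O=C1O/C(=C\Cn2cc(-c3ccc(Br)cc3)nn2)C(OCc2ccccc2)=C1OCc1ccccc1` and compound 2 `O=C1O/C(=C\Cn2cc(-c3cc(F)cc(F)c3)nn2)C(OCc2ccccc2)=C1OCc1ccccc1` share one core and differ only in the group carried on an aromatic carbon. In an ADME assay on HFF cells (Homo sapiens) for cytotoxicity, read by MTT assay, with a stated time of 72 h (on this read-out lower numbers stand for stronger inhibition and higher numbers for weaker inhibition), compound 1 gives > 100000 nM, which is a limit of the assay and not a number. Compound 2 in this assay gives > 100000 nM, likewise a limit. The step that the two limits leave unreadable from compound 1 to compound 2 therefore cannot be read. Compound 2 stands at the limit of > 100000 nM in this assay, at which 2 of the 2 values shown sit, which is all the numbers shown allow to be said of it.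

Compound 3 `CCCCCc1ccc(-c2cn(C/C=C3\OC(=O)C(OCc4ccccc4)=C3OCc3ccccc3)nn2)cc1` is not yet measured. It differs from compound 2 by 4-pentylphenyl in place of 3,5-difluorophenyl on an aromatic carbon. Within the data shown here, the only measured step at this place is a step that the two limits leave unreadable from compound 1 to compound 2, and it is unreadable; no measured step gives a size for a swap of this kind. Both compounds with a swap here returned limits, so compound 3 is expected to sit at or near that limit as well, with no step beyond the scatter, the expected step being a step that the limit leaves unreadable from compound 2 to compound 3. Compound 3 is therefore estimated at 150000 nM in this assay, within 50000 nM to 500000 nM, most probably reported again only as a limit.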

Compound 3, half-maximal inhibitory concentration: > 100000 nM
Compound 3: only a limit was reported; the forecaster's own chance of this, stated with the estimate: 80%; the middle value does not contradict the limit.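

In this assay compound 3 gives > 100000 nM, again a limit of the assay and not a number. No new step can be read among compound 1, compound 2 and compound 3. The compounds shown leave open whether the group on the aromatic carbon changes cytotoxicity at all, since all values share one limit: the limit of > 100000 nM in this assay, at which 3 of the 3 values shown sit.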